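Piperazine sulfonamide series: aryl groups on the ring amine

This account rests on a few compounds, and the source may have more. Where it says the series, first, only, none or still open, it means among the compounds named here.

The series shares the core of compound 1 `O=C1Cc2cc(S(=O)(=O)N3CCNCC3)ccc2N1`. In an assay on isolated protein for inhibition of lysosomal alpha-glucosidase (Homo sapiens), read by fluorescence, with stated times of 5 min and 45 min (on this read-out lower numbers stand for stronger inhibition and higher numbers for weaker inhibition), compound 1 is reported as "not active" (no number reported), and no number stands for it. Compound 2 `O=C1Cc2cc(S(=O)(=O)N3CCN(c4ccc(O)cc4)CC3)ccc2N1` in this assay gives 1880 nM. Compound 3 `Cc1ccc(N2CCN(S(=O)(=O)c3ccc4c(c3)CC(=O)N4)CC2)cc1` is not yet measured; relative to compound 1 it carries 4-methylphenyl in place of hydrogen on an amine nitrogen in a ring. No step between measured compounds is shown, so the size of the move from compound 1 is unknown; a measurable, stronger read-out than the inactive compound 1 is expected, beyond the scatter. Because compound 2 gives 1880 nM, a value of similar order is expected. Compound 3 is estimated at 3000 nM in this assay, within 700 nM to 13000 nM.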

Compound 3, half-maximal inhibitory concentration: "not active" (no number reported)
Nothing numeric was reported for compound 3; there is nothing to compare the estimate with.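

No step can be read from compound 1 to compound 3, as neither carries a number. No evidence bears on this result. The compounds shown leave open how far an aryl group on the ring amine moves inhibition.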